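From Propylsulfanyl to 4-Aminopiperidinyl on a Shared Core

The source may report more compounds than this note shows. Statements on the series, on what has been measured and on what is new or still open speak of the compounds shown alone.

Measured in a functional assay for inhibition of sodium/hydrogen exchanger (Oryctolagus cuniculus); a lower number here means a stronger inhibitor, a higher number a weaker inhibitor:
Compound 1 `Cc1c(C(=O)N=C(N)N)cc(S(C)(=O)=O)c(Cl)c1Cl`: 29 nM
Compound 2 `Cc1c(C(=O)N=C(N)N)cc(S(C)(=O)=O)c(Cl)c1C`: 58 nM
Compound 3 `CCCSc1cc(C)c(C(=O)N=C(N)N)cc1S(C)(=O)=O`: 6.8 nM

Compound 3 stands at the lowest of the three numbers. Its nearest neighbour is compound 1, which gives 29 nM; compound 2 lies furthest off at 58 nM.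

Compound 4 `Cc1cc(N2CCC(N)CC2)c(S(C)(=O)=O)cc1C(=O)N=C(N)N` differs from compound 3 in one place: 4-aminopiperidin-1-yl in place of propylsulfanyl on an aromatic carbon. Within the data shown here, the only measured step, a 2.0-fold higher number from compound 1 to compound 2 (0.30 log units; within the scatter), concerns methyl in place of chloro on an aromatic carbon and leaves the propylsulfanyl group untouched, so it does not bear on this change. Nothing measured shows what the 4-aminopiperidin-1-yl group does. Since compound 3 holds the lowest number, a rise toward the other values is judged more likely than a further drop. The step expected is a 2.9-fold higher number from compound 3 to compound 4 (0.47 log units; beyond the scatter). Compound 4 is estimated at 20 nM, with a range of 5 nM to 80 nM.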

Compound 4, half-maximal inhibitory concentration: 9.8 nM
The estimate for compound 4 lay 2.0-fold (0.31 log units) above the measured number; the measured number falls inside the stated range.
By their numbers in this assay, from the lowest: compounds 3 and 4 (each within the scatter of the next); then compounds 1 and 2 (each within the scatter of the next).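

In this assay the aromatic carbon ortho to the methylsulfonyl group takes 4-aminopiperidin-1-yl in place of propylsulfanyl with a 1.4-fold higher number from compound 3 to compound 4 (0.16 log units; within the scatter) as the step. This position therefore holds either an open chain or a six-membered non-aromatic ring bearing an amine, with no change beyond the scatter. Nothing available explains why the two groups read alike. The compounds shown leave open whether the ring's amine matters here, a question that a plain piperidin-1-yl group or a carboxylic acid in its place would address.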